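Removing the Bromine from an Inactive Ester Scaffold

The source may report more compounds than this note shows. Statements on the series, on what has been measured and on what is new or still open speak of the compounds shown alone.

The study rests on a shared core, first seen as compound 1 `C=C1C[C@]23C[C@@]1(O)CC[C@H]2c1cc2c(C(=O)O)coc2c(C)c1[C@@H]3C(=O)O`. In a functional assay on RCK8 cells (Homo sapiens) for cytotoxicity, read by luminescence and CellTiter-Glo, with a stated time of 24 h (a higher number here means a weaker inhibitor, a lower number a stronger inhibitor), compound 1 reaches only a limit of the assay, > 10000 nM. Compound 2 `C=C1C[C@]23C[C@@]1(O)CC[C@H]2c1cc(Br)c(O/C=C/C(=O)OC)c(C)c1[C@@H]3C(=O)OC` is built on the same core. In this assay compound 2 likewise reaches only a limit, > 10000 nM. Compound 2 thus stands at the limit of > 10000 nM in this assay, at which 2 of the 2 values shown sit, with no numerical value to set it apart from compound 1. Compound 3 `C=C1C[C@]23C[C@@]1(O)CC[C@H]2c1ccc(O/C=C/C(=O)OC)c(C)c1[C@@H]3C(=O)OC` differs from compound 2 in one place: hydrogen in place of bromo on an aromatic carbon. Going by the values given here, no measured pair shows what this change does, and with compound 2 already resting at a limit, the step is expected to be a step that the limit leaves unreadable from compound 2 to compound 3, none beyond the scatter in any readable direction. Compound 3 is therefore estimated to give 15000 nM in this assay, within a range from 5000 nM to 50000 nM, most probably again as a limit rather than a number.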

Compound 3, half-maximal inhibitory concentration: > 10000 nM
Compound 3 gave a limit, no number; the forecaster's own chance of this, stated with the estimate: 80%; the middle value does not contradict the limit.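

Compound 2 and compound 3 both rest at a limit rather than a number, so no step between them can be read: the limit of > 10000 nM in this assay, at which 3 of the 3 values shown sit.

The compounds shown leave open what hydrogen in place of bromo does, and whether any compound on the shared core gives a number in this assay.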